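Moving the aromatic ring one carbon along the chain

A few compounds are considered here, and "the series" means these few. Any claim that something is new, unique, unknown or untested is made for them only; others in the source may bear on it.

Compound 3 `Cc1ccc(CC(C)CNC(=O)/N=C(\N)NCCCc2sc(N)nc2C)cc1` gives the lowest of the three numbers in an assay on membranes from Sf9 cells for displacement of a labelled ligand from histamine H2 receptor (Homo sapiens), read by scintillation counting, with a stated time of 60 min (on this read-out lower numbers stand for stronger inhibition and higher numbers for weaker inhibition), namely 72.4 nM. Compound 1 `N/C(=N\C(=O)NC1CCCCC1)Nc1cccc(-c2csc(N)n2)c1` gives 4470 nM and compound 2 `CCCNC(=O)/N=C(\N)Nc1cccc(-c2csc(N)n2)c1` gives 5250 nM; the change between them, propyl in place of cyclohexyl on an amide-type nitrogen, produced a 1.2-fold higher number from compound 1 to compound 2 (0.07 log units; within the scatter). Compound 4 `Cc1nc(N)sc1CCCN/C(N)=N/C(=O)NCC(C)CCc1ccccc1` differs from compound 3 by benzyl in place of 4-methylphenyl on a saturated chain carbon, three bonds along the chain from an amide-type nitrogen. Going by the values given here, no measured step touches this part of the chain, and the only step that is known, at the amide-type nitrogen, stayed within the scatter. Compound 4 is therefore expected to give a number close to that of compound 3, with a 1.4-fold higher number from compound 3 to compound 4 (0.14 log units; within the scatter), that is an estimated 100 nM with a range from 40 nM to 250 nM.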

Compound 4, inhibition constant: 63.1 nM
Beside the measured number, compound 4's estimate is 1.6-fold (0.20 log units) above it; the range from low to high includes it.
By their numbers in this assay, from the lowest: compounds 4 and 3 (each within the scatter of the next); then compounds 1 and 2 (each within the scatter of the next).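

In this assay the change gave a 1.1-fold lower number from compound 3 to compound 4 (0.06 log units; within the scatter) and so shows that the same atoms can be rearranged at this place, from 4-methylbenzyl to phenethyl, without a change beyond the scatter. Going by these compounds alone, the earlier step concerned only the amide-type nitrogen, so this is the first reading on this part of the chain. No evidence is available to explain this result.

From the compounds shown here alone, whether a longer chain in place of phenethyl would keep the number this low remains open. So does the effect of an amine or a carboxylic acid on the aromatic ring.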